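Methyl on the phenyl of compound 3: an expected potency

The source may report more compounds than this note shows. Statements on the series, on what has been measured and on what is new or still open speak of the compounds shown alone.

Compound 3 `COc1cc2c(Oc3ccc(NC(=O)c4nccc(-c5ccccc5)n4)cc3F)ccnc2cc1OCCCN1CCCCC1` gives 1030 nM in a functional assay on MKN-45 cells (Homo sapiens) for cytotoxicity, read by MTT assay, with a stated time of 72 h (a lower number here means a stronger inhibitor, a higher number a weaker inhibitor), the highest of the three numbers in hand. Compound 1 `COc1cc2c(Oc3ccc(NC(=O)c4cc(-c5ccc(F)cc5)ccn4)cc3F)ccnc2cc1OCCCN1CCCC1` gives 350 nM and compound 2 `COc1cc2c(Oc3ccc(NC(=O)c4cc(-c5ccccc5)ccn4)cc3F)ccnc2cc1OCCCN1CCCCC1` gives 270 nM. Compounds 1 and 2 differ in two places, so their values stand only side by side. Among the measured compounds shown here, the single one-place step, a 3.8-fold higher number from compound 2 to compound 3 (0.58 log units; beyond the scatter), concerns the ring on the carbonyl carbon, not the phenyl. Compound 4 `COc1cc2c(Oc3ccc(NC(=O)c4nccc(-c5ccc(C)cc5)n4)cc3F)ccnc2cc1OCCCN1CCCCC1` differs from compound 3 by methyl in place of hydrogen on an aromatic carbon. For the measured compounds named here, no measured pair shows this change, so nothing here points in either direction. Compound 4 is therefore expected to move by a 1.1-fold lower number from compound 3 to compound 4 (0.06 log units; within the scatter), a step within the scatter. The estimate for compound 4 is 900 nM, with a range from 400 nM to 2200 nM.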

Compound 4, half-maximal inhibitory concentration: 580 nM
Beside the measured number, compound 4's estimate is 1.6-fold (0.19 log units) above it, within the range that was stated.
By their numbers in this assay, from the lowest: compounds 2, 1, 4 and 3 (each within the scatter of the next, the first and the last beyond it).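

In this assay, among the compounds shown here, the change from phenyl to 4-methylphenyl gives a 1.8-fold lower number from compound 3 to compound 4 (0.25 log units; within the scatter) and is the first one-place reading of a group on this phenyl. Methyl on this aromatic carbon, para to a large group, thus leaves compound 4 within the scatter of compound 3. Nothing measured here bears on the cause of this step.

The compounds shown leave open how a longer chain such as propyl, an amine or a carboxylic acid would read at this place. They also leave open whether methyl would read the same on the phenyl of compound 2.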